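The compounds below may be only part of what the source reports. "The series", "measured", "known", "first", "only" and "open" are said of these compounds alone.

For the measured compounds named here, compound 3 `Cc1ccc2cccc(NC(=O)c3cnccn3)c2n1` stands at > 10000 nM in a functional assay on MIA PaCa-2 cells (Homo sapiens) for inhibition, read by MTT assay, with a stated time of 72 h (on this read-out lower numbers stand for stronger inhibition and higher numbers for weaker inhibition), as its only reading, and that is a limit, not a number. Compound 2 `Cc1cnc(C(=O)Nc2cccc3ccc(C)nc23)cn1` gives > 10000 nM in this assay as well, and this too is a limit. What connects them is a step that the two limits leave unreadable from compound 2 to compound 3 and so no size can be carried over from it. The measured picture for these two compounds rests on the limit of > 10000 nM in this assay, at which 2 of the 3 values shown sit, and offers no number for either.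

Compound 4 `Cc1ccc2cccc(NC(=O)c3ncccn3)c2n1` comes from compound 3 by a single swap, pyrimidin-2-yl in place of pyrazin-2-yl on a carbonyl carbon with pyrimidin-2-yl in place of pyrazin-2-yl on a carbonyl carbon. Going by the values given here, no measured step covers this swap directly. The nearest guide is compound 1 `O=C(Nc1cccc2cccnc12)c1ncccn1` which carries the same pyrimidin-2-yl and gives 330 nM in this assay as a true number, but it has no methyl on the shared core, whereas compound 4 keeps that methyl. Some gain in inhibition is therefore expected, with real doubt about how much. The expected step of an at least 3.3-fold lower number from compound 3 to compound 4 (0.52 log units; beyond the scatter) points toward stronger inhibition, and its size is loose since the starting point is only a limit. For compound 4 the estimated value is 3000 nM with an expected range from 500 nM to 15000 nM in this read-out.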

Compound 4, half-maximal inhibitory concentration: > 10000 nM
Compound 4: a limit, no number; the forecaster's own chance of this, stated with the estimate: 40%; at least 3.3-fold (0.52 log units) between middle value and limit.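

The swap of pyrazin-2-yl for pyrimidin-2-yl on the carbonyl carbon leaves the methyl-bearing core at the assay limit, so the steps among compound 2, compound 3 and compound 4 cannot be read, and neither ring can be ranked over the other on this core. For the compounds shown here, the new pairing does give a size for the methyl itself, with methyl in place of hydrogen on an aromatic carbon as the only change: in this assay, the result is an at least 30-fold higher number from compound 1 to compound 4 (1.48 log units; beyond the scatter). Even the pyrimidin-2-yl that goes with a true number on the core of compound 1 no longer gives one once this methyl is present, and the methyl-bearing compounds all share one ceiling: the limit of > 10000 nM in this assay, at which 3 of the 4 values shown sit.

The compounds shown leave open how another group on that same aromatic carbon, such as an amine, a chlorine atom or an ethyl group, would read on the otherwise unchanged core of compound 1. They also leave open how pyrazin-2-yl on the carbonyl carbon would read on that core without the methyl, which is the pairing that could put a number on the ring swap.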